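Replacing a sulfonamide chain with a sulfonic acid

A few compounds are considered here, and "the series" means these few. Any claim that something is new, unique, unknown or untested is made for them only; others in the source may bear on it.

Of the compounds shown here, three sharing one core have been tested in an assay for binding affinity to adenosine receptor A1 (Rattus norvegicus), read by radioligand binding; on this read-out lower numbers stand for stronger inhibition and higher numbers for weaker inhibition. Compound 1 `CCn1c(=O)c2nc(-c3cccc(S(=O)(=O)NCCN(C)C)c3)[nH]c2n(CC)c1=O` gives 553 nM, the highest of the three numbers. Compound 2 `CCCn1c(=O)c2nc(-c3ccccc3N)[nH]c2n(CCC)c1=O` gives 41 nM, and compound 3 `CCn1c(=O)c2nc(-c3ccc(S(=O)(=O)NCCCN(C)C)cc3)[nH]c2n(CC)c1=O` gives 70 nM; both gaps to compound 1 lie beyond the usual scatter, so compound 1 is the weakest binder of the three. Compound 4 `CCn1c(=O)c2nc(-c3cccc(S(=O)(=O)O)c3)[nH]c2n(CC)c1=O` differs from compound 1 in one place: hydroxy in place of (2-(dimethylamino)ethyl)amino on a sulfonyl sulfur. Going by the values given here, no measured pair differs by only this change, so there is no measured step to lean on. The expected step is a 5.4-fold higher number from compound 1 to compound 4 (0.73 log units; beyond the scatter), toward a higher number beyond the scatter. Compound 4 is expected to come out near 3000 nM, within a range from 600 nM to 15000 nM.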

Compound 4, half-maximal inhibitory concentration: 30700 nM
The estimate for compound 4 lay 10-fold (1.01 log units) below the measured number, and the stated range ends below it.
By their numbers in this assay, from the lowest: compounds 2 and 3 (each within the scatter of the next); then compound 1; then compound 4.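

On a sulfonyl sulfur, this position does not tolerate every group equally: in this assay, hydroxy in place of (2-(dimethylamino)ethyl)amino gives a 56-fold higher number from compound 1 to compound 4 (1.74 log units; beyond the scatter), a large weakening from a compound that was already the highest number among the earlier three. Nothing measured here explains why the step is so large.

Still open, on these data alone, is whether the loss of the chain or the arrival of hydroxy drives this step. A plain amino group on the sulfur, or a carboxylic acid in place of the sulfo group, could help separate the two.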